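Trading a Chlorothiophene for Methyl on a Shared Core

The source may report more compounds than this note shows. Statements on the series, on what has been measured and on what is new or still open speak of the compounds shown alone.

Two compounds have been measured in an assay on isolated protein for binding affinity to sphingosine 1-phosphate receptor 2 (Homo sapiens), read by surface plasmon resonance; on this read-out higher numbers stand for weaker binding and lower numbers for tighter binding:

compound 1, `Cn1ncc2c(-c3ccc(F)cc3)cc(NNC(=O)Nc3cc(Cl)cc(Cl)c3)nc21`, gives 4980 nM
compound 2, `Cc1nn(C)c2nc(NNC(=O)Nc3cc(Cl)nc(Cl)c3)cc(-c3ccc(Cl)s3)c12`, gives 1980 nM

Both share a core carrying a urea-linked dichlorinated aromatic ring on one side and a second aromatic group on the other. Compound 2 has the lower of the two numbers in this assay, which here means the tighter binding, and its gap to compound 1 is beyond the usual scatter of repeated measurements.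

Compound 3, `Cc1cc(NNC(=O)Nc2cc(Cl)nc(Cl)c2)nc2c1c(C)nn2C`, has not been measured yet. It keeps the core of compound 2 and changes one group: methyl in place of 5-chlorothiophen-2-yl on an aromatic carbon. In plain terms, a ring bearing a chlorine gives way to a single carbon.

Going by the values given here, no measured pair shows what this kind of swap does, so the expectation rests only on the fact that a sizeable aromatic group disappears. The step from compound 2 to compound 3 is expected to weaken binding, as a 3.0-fold higher number from compound 2 to compound 3 (0.48 log units; beyond the scatter). Compound 3 is therefore estimated to give about 6000 nM in this assay, with a plausible range from 2000 nM to 20000 nM.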

Compound 3, dissociation constant: 11000 nM
The estimate for compound 3 lay 1.8-fold (0.26 log units) below the measured number, and the stated range covers the measured number.
By their numbers in this assay, from the lowest: compound 2; then compound 1; then compound 3.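

In this assay, putting methyl in place of 5-chlorothiophen-2-yl on the aromatic carbon opposite the ring nitrogen weakens binding (a 5.6-fold higher number from compound 2 to compound 3 (0.74 log units; beyond the scatter)). This is the only pair shown that differs in one place, so it gives the first direct reading of this position: with the rest of the molecule held constant, the group on this carbon affects binding, and the larger chlorinated aromatic group goes with tighter binding than the single carbon of methyl. The data offer no measured explanation for this loss of binding.

The swap removes a ring, a sulfur and a chlorine at once, so the compounds shown leave open which of these parts matters, a question that an unsubstituted thiophene, a phenyl ring or an ethyl group on the same carbon could help to answer. They also leave open whether a group carrying an amine or a carboxylic acid at this position would bind more tightly or more weakly than either 5-chlorothiophen-2-yl or methyl.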